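The compounds below may be only part of what the source reports. "The series", "measured", "known", "first", "only" and "open" are said of these compounds alone.

Working notes on the series. Compound 1 `COc1ccccc1N1CCN(CCn2nc(-n3cnc4ccccc43)ccc2=O)CC1` is measured in an assay on cell membranes from brain for binding affinity to Adrenergic receptor alpha-1 (Rattus norvegicus), read by radioligand binding (on this read-out lower numbers stand for stronger inhibition and higher numbers for weaker inhibition), where compound 1 gives 33 nM. Among the three numbers in hand compound 1 stands second highest: compound 2 `O=c1ccc(-n2cnc3ccccc32)nn1CCN1CCN(c2ccccc2Cl)CC1` gives 70.4 nM, and compound 3 `O=c1ccc(-n2cnc3ccccc32)nn1CCCCN1CCN(c2ccccc2Cl)CC1` gives 1.3 nM, the lowest of the set. For the measured compounds named here, the only single-site step measured so far is a 2.1-fold higher number from compound 1 to compound 2 (0.33 log units; beyond the scatter). Compound 4 `COc1ccccc1N1CCN(CCn2nc(-n3ccnc3)ccc2=O)CC1` is not yet measured; it differs from compound 1 by 1H-imidazol-1-yl in place of 1H-benzimidazol-1-yl on an aromatic carbon. Going by the values given here, no measured step touches this exchange, and the step from compound 1 to compound 2 concerns a different site, so it gives no guide to size or direction. With the smaller entering group, a modest weakening is the expectation. Compound 4 is estimated at 80 nM, range 25 nM to 300 nM. The expected step is a 2.4-fold higher number from compound 1 to compound 4 (0.38 log units; beyond the scatter).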

Compound 4, inhibition constant: 237 nM
The estimate for compound 4 lay 3.0-fold (0.47 log units) below the measured number; the range from low to high includes it.
By their numbers in this assay, from the lowest: compound 3; then compound 1; then compound 2; then compound 4.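

At this position, on an aromatic carbon next to the ring nitrogen, 1H-imidazol-1-yl in place of 1H-benzimidazol-1-yl gives a 7.2-fold higher number from compound 1 to compound 4 (0.86 log units; beyond the scatter), a larger step than the one at the other site, a 2.1-fold higher number from compound 1 to compound 2 (0.33 log units; beyond the scatter). The exchange takes away the six-membered aromatic ring of carbon only, while the counts of hydrogen-bond donors and acceptors stay the same. Nothing measured accounts for the size of this step. On these data alone, whether phenyl or an amine at this position would give a lower number remains open. Also open, as far as these compounds go, is whether the step would carry over to the chloro compound 3, with its longer chain.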